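One added methoxy on the core of compound 1

The compounds below may be only part of what the source reports. "The series", "measured", "known", "first", "only" and "open" are said of these compounds alone.

Compounds in a physicochemical assay for solubility, read by HPLC, in phosphate buffer, with a stated time of 16 h, at pH 6.8; on this read-out lower numbers stand for lower solubility and higher numbers for higher solubility:
Compound 1 `Cc1ccc([C@H](C)NC(=O)Cn2nnc3ccccc3c2=O)cc1`: 12000 nM
Compound 2 `C[C@H](NC(=O)Cn1nnc2ccccc2c1=O)c1ccc(Br)cc1`: 900 nM
Compound 3 `COc1ccc2c(=O)n(CC(=O)N[C@@H](C)c3ccc(C)cc3)nnc2c1`: not yet measured

Of the two measured compounds, compound 1 holds the higher number, at 12000 nM. Compound 3 keeps the whole of compound 1 and changes it in one place: methoxy in place of hydrogen on an aromatic carbon. In words, this is methoxy in place of hydrogen on an aromatic carbon, on a six-membered aromatic ring of carbon only that is part of a fused system of two rings.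

Among the compounds with values here, only one measured step is available, a 13-fold lower number from compound 1 to compound 2 (1.12 log units; beyond the scatter), and it is a different change at a different place, bromo in place of methyl on an aromatic carbon. It shows that a single substitution on an aromatic carbon can move the number in this assay by a large amount in this small set, but it says nothing direct about methoxy on the core. No step beyond the scatter is therefore expected, with only a slight lean towards a lower number. The expected step is a 1.5-fold lower number from compound 1 to compound 3 (0.18 log units; within the scatter). For compound 3 the estimated value is 8000 nM, with an expected range of 2500 nM to 20000 nM.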

Compound 3, solubility: 1000 nM
Estimate against measurement, compound 3: 8.0-fold (0.90 log units) above; measured number below the stated range.
By their numbers in this assay, from the lowest: compounds 2 and 3 (each within the scatter of the next); then compound 1.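

In this assay, the shared core turns out to be a sensitive place: methoxy in place of hydrogen on an aromatic carbon of the six-membered aromatic ring of carbon only goes with a 12-fold lower number from compound 1 to compound 3 (1.08 log units; beyond the scatter). Within the data shown here, the only earlier step, a 13-fold lower number from compound 1 to compound 2 (1.12 log units; beyond the scatter), came from a change on a different aromatic carbon, so it showed nothing about the core, whereas this step shows that the number also moves with a single substitution at this position. Nothing measured here accounts for the step, which therefore stands as an observation without an explanation.

The compounds shown leave open whether this lower number belongs to methoxy itself or would appear with any group at this position, a question that a hydroxy group, an amine or a carboxylic acid on the same carbon could help to settle. Also open, going by these compounds, are whether the other aromatic carbons of this ring respond in the same way, and whether methoxy at this position would give a step of similar size with bromo in place of methyl, as in compound 2.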